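The compounds below may be only part of what the source reports. "The series", "measured", "known", "first", "only" and "open" are said of these compounds alone.

Compound 1 `O=C1C=C(NC2CCCCC2)C(=O)c2c1nc1n2[C@H]2OC[C@@H](O)[C@H]2OC1`: > 16000 nM
Compound 2 `O=C1C(NC2CC2)=CC(=O)c2c1nc1n2[C@H]2OC[C@@H](O)[C@H]2OC1`: > 16000 nM

Both measured compounds share one core and differ only in the group on the amine nitrogen. In a functional assay on HeLa cells (Homo sapiens) for inhibition, read by sulforhodamine B assay (on this read-out higher numbers stand for weaker inhibition and lower numbers for stronger inhibition), compound 1 gives > 16000 nM, which is a limit of the measurement rather than a number. Compound 2 gives > 16000 nM in this assay, again only a limit. So compound 1 stands at a limit and nothing more; the one thing known is the limit of > 16000 nM in this assay, at which 2 of the 2 values shown sit. Compound 3 `COc1cccc(NC2=CC(=O)c3nc4n(c3C2=O)[C@H]2OC[C@@H](O)[C@H]2OC4)c1` has not yet been measured. It differs from compound 1 by 3-methoxyphenyl in place of cyclohexyl on an amine nitrogen. Among the measured compounds shown here, no step between measured compounds exists, so no size of effect can be read off; I expect the change from compound 1 to compound 3 to stay within the scatter, most likely leaving compound 3 at the limit too, a step of a number no higher from compound 1 to compound 3 (the limit leaves the size open). Compound 3 is estimated at 16000 nM, in a range from 6000 nM to 40000 nM.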

Compound 3, half-maximal inhibitory concentration: 4280 nM
Estimate against measurement, compound 3: 3.7-fold (0.57 log units) above; measured number below the stated range.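

In this assay, 3-methoxyphenyl in place of cyclohexyl on the amine nitrogen gives an at least 3.7-fold lower number from compound 1 to compound 3 (0.57 log units; beyond the scatter), so the group at this position can move the read-out towards stronger inhibition. Compound 3 gives a measured number, whereas the other values shown are only a limit of the measurement: the limit of > 16000 nM in this assay, at which 2 of the 3 values shown sit.

Because compound 1 sits at that limit, the step sets only a minimum, and the true size of the change may be larger. The swap also changes two things at once, an aromatic ring replacing a non-aromatic one and a methoxy group being added, and the compounds shown cannot separate the two. A plain phenyl group on the same nitrogen would show whether the ring alone accounts for the step, while a benzyl group would show whether the ring tolerates a carbon spacer.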